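The compounds below may be only part of what the source reports. "The series", "measured", "known", "first", "only" and "open" are said of these compounds alone.

Working notes on the series in a functional assay on SGC-7901 cells (Homo sapiens) for antiproliferative activity, read by MTT assay, with a stated time of 72 h; on this read-out higher numbers stand for weaker inhibition and lower numbers for stronger inhibition. Compound 1 `Cc1nn(C)c(Oc2ccc(Br)cc2)c1/C=N\OCc1c(Cl)c(-c2ccc(Cl)cc2)nn1C` gives 5960 nM in this assay. Compound 2 `Cc1ccc(Oc2c(/C=N\OCc3c(Cl)c(-c4ccc(Cl)cc4)nn3C)c(C)nn2C)cc1` gives 3730 nM in this assay. The step of a 1.6-fold lower number from compound 1 to compound 2 (0.20 log units; within the scatter) leaves the two compounds indistinguishable on these numbers. Going by the values given here, compound 2 thus carries the lowest of the two numbers so far, but its only neighbour is compound 1 and the gap is within the scatter, so no order between them can be read.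

The next step goes to compound 3 `COc1ccc(Oc2c(/C=N\OCc3c(Cl)c(-c4ccc(Cl)cc4)nn3C)c(C)nn2C)cc1`, which is not yet measured. Compound 3 differs from compound 2 by methoxy in place of methyl on an aromatic carbon. Among the compounds with values here, the only measured step that bears on this change is the one at the same place, a 1.6-fold lower number from compound 1 to compound 2 (0.20 log units; within the scatter), which stayed within the scatter; no measured step exchanges methyl for methoxy, so the expectation rests on that single step. A step of no more than the scatter is therefore expected, a 1.0-fold lower number from compound 2 to compound 3 (0.00 log units; within the scatter), in no particular direction. The estimate for compound 3 in this assay is 3700 nM, with a range from 1500 nM to 9000 nM.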

Compound 3, half-maximal inhibitory concentration: 2010 nM
For compound 3 the middle estimate is 1.8-fold (0.27 log units) above the measured one; the range from low to high includes it.
By their numbers in this assay, from the lowest: compounds 3, 2 and 1 (each within the scatter of the next, the first and the last beyond it).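

In this assay the exchange of methyl for methoxy gives a 1.9-fold lower number from compound 2 to compound 3 (0.27 log units; within the scatter) and so does not separate the two compounds, as was already the case for the exchange of bromo for methyl at this place. Going by these compounds alone, the exchange of bromo for methoxy, on the same aromatic carbon para to a large group, gives a 3.0-fold lower number from compound 1 to compound 3 (0.47 log units; beyond the scatter) and is the first step at this position to lie beyond the scatter, although it is modest in size. The position therefore responds to what it carries, but only across the pair of bromo and methoxy, with methyl within the scatter of both. No measured evidence accounts for this step, and the numbers alone give no reason for it.

The compounds shown cover only bromo, methyl and methoxy at this position, so it remains open whether an amine, a carboxylic acid or a longer chain such as ethoxy would extend the step seen with methoxy or reverse it. Going by these compounds, whether the same exchange would give a step of similar size on a different remainder of the molecule also stays open, as all three compounds share the rest of their structure.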